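Azetidine amide with a ring amine: an unmeasured neighbour

The source may report more compounds than this note shows. Statements on the series, on what has been measured and on what is new or still open speak of the compounds shown alone.

The measured compounds:
compound 1 `CC1CCCC(C(=O)N2CC(c3nc(-c4cccc(Cl)c4)no3)C2)C1` gives > 10000 nM in an assay on HEK293 cells for negative allosteric modulation of metabotropic glutamate receptor 5 (Homo sapiens), read by FLIPR; on this read-out lower numbers stand for stronger inhibition and higher numbers for weaker inhibition
compound 2 `O=C(N1CCCCCC1)N1CC(c2nc(-c3cccc(Cl)c3)no2)C1` gives > 10000 nM in this assay

Compound 1 shows only a limit of the assay, not a number. Compound 2 likewise stands at a limit, not a number, so on the numbers shown nothing places it anywhere in particular. Within the data shown here, both measured values sit at the limit of > 10000 nM in this assay, at which 2 of the 2 values shown sit, and the only step between measured compounds, a step that the two limits leave unreadable from compound 1 to compound 2, is therefore unreadable in size. Compound 3 `COC1CCN(C(=O)N2CC(c3nc(-c4cccc(Cl)c4)no3)C2)CC1` differs from compound 2 by 4-methoxypiperidin-1-yl in place of azepan-1-yl on a carbonyl carbon. Among the measured compounds shown here, no measured step of readable size bears on this change; the one step available is the unreadable one just named. Compound 3 is accordingly expected to remain near the limit, with a number no higher from compound 2 to compound 3 (the limit leaves the size open) estimated as no step beyond the scatter. The estimate for compound 3 is 10000 nM, within 2500 nM to 40000 nM.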

Compound 3, half-maximal inhibitory concentration: > 10000 nM
Compound 3: only a limit was reported; the forecaster's own chance of this, stated with the estimate: 70%; the middle value lies on the limit itself.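

In this assay compound 3 gives > 10000 nM, a limit and not a number. No step among compound 1, compound 2 and compound 3 can be read, since all stand at one limit: the limit of > 10000 nM in this assay, at which 3 of the 3 values shown sit.

The compounds shown leave open which group on the carbonyl carbon, if any, would give a readable number.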